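Adding an Unsaturated Ester to a Cytotoxic Scaffold

The source may hold more compounds than are shown below. What is called first, only, known or untested is meant among the compounds shown, and "the series" means these compounds.

Measured compounds:
- Compound 1 `C=C1C(=O)O[C@@H]2[C@@H]3[C@@]4(C=C[C@@]3(C)[C@]3(C4)C(=O)O[C@@H]4[C@H]5C(C)=CC[C@H]5[C@](C)(O)C[C@H](O)[C@H]43)[C@](C)(O)CC[C@@H]12`: in a functional assay on SUNE1 cells (Homo sapiens) for cytotoxicity, read by MTT assay, with a stated time of 48 h (on this read-out higher numbers stand for weaker inhibition and lower numbers for stronger inhibition), compound 1 gives > 10000 nM, which is a limit of the assay rather than a number.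
- Compound 2 `C/C=C(\C)C(=O)O[C@H]1C[C@@](C)(O)[C@]23C=C[C@](C)([C@@H]2[C@H]2OC(=O)[C@@H](C)[C@@H]21)[C@]1(C3)C(=O)O[C@@H]2[C@H]3C(C)=CC[C@H]3[C@](C)(O)C[C@H](O)[C@H]21`: in this assay compound 2 gives > 10000 nM, again a limit.
- Compound 3 `C=C1C(=O)O[C@H]2[C@H]1[C@@H](O)C[C@@](C)(O)[C@]13C=C[C@](C)([C@H]21)[C@]1(C3)C(=O)O[C@@H]2[C@H]3C(C)=CC[C@H]3[C@](C)(O)C[C@H](OC(=O)/C(C)=C\C)[C@H]21`: in this assay compound 3 gives > 10000 nM, also a limit.

Compound 1 therefore stands at the ceiling of what this assay can report; no number was reached for it, and the same holds for the other two measured compounds, as the limit of > 10000 nM in this assay, at which 3 of the 3 values shown sit, shows. Within the data shown here, no step between measured compounds can be compared, since none of them differs from another in only one place.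

Compound 4 `C=C1C(=O)O[C@@H]2[C@@H]3[C@@]4(C=C[C@@]3(C)[C@]3(C4)C(=O)O[C@@H]4[C@H]5C(C)=CC[C@H]5[C@](C)(O)C[C@H](OC(=O)/C(C)=C/C)[C@H]43)[C@](C)(O)CC[C@@H]12` is the unmeasured partner of compound 1. The change is (1-methylprop-1-en-1-yl)carbonyl in place of hydrogen on an oxygen on a saturated carbon, so that the hydroxy of compound 1 becomes a ((1-methylprop-1-en-1-yl)carbonyl)oxy group. Compounds 2 and 3 already carry a related (1-methylprop-1-en-1-yl)carbonyl ester on the shared core and both sit at the limit, which gives no sign that this ester brings a readable number.

The step from compound 1 to compound 4 is expected to be a step that the limit leaves unreadable from compound 1 to compound 4, nothing beyond the scatter. Compound 4 is estimated at 15000 nM, with a range from 7000 nM to 40000 nM, most likely reported only as a limit.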

Compound 4, half-maximal inhibitory concentration: > 10000 nM
Compound 4: only a limit was reported; the forecaster's own chance of this, stated with the estimate: 85%; the middle value does not contradict the limit.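

Compound 4 gives > 10000 nM, which is a limit and not a number. Among these compounds, compound 1 also rests at a limit, and no step between compound 1 and compound 4 can be read. The compounds shown leave open whether hydroxy to ((1-methylprop-1-en-1-yl)carbonyl)oxy changes anything, and what actual number any of them would reach in this assay.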